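Trading halogen places on a sulfonamide phenyl group

The source may hold more compounds than are shown below. What is called first, only, known or untested is meant among the compounds shown, and "the series" means these compounds.

Compound 1 `O=S(=O)(Nc1ccccc1Cl)c1ccc(-c2cnc(C3CC3)o2)cc1` gives 49700 nM in the measurements so far
Compound 2 `O=S(=O)(Nc1ccc(F)c(Cl)c1)c1ccc(-c2cnc(C3CC3)o2)cc1` gives 73700 nM in the measurements so far

In a functional assay on cells (leukaemia cell line, Homo sapiens) for inhibition, read by sulforhodamine B assay, with a stated time of 48 h (on this read-out lower numbers stand for stronger inhibition of growth and higher numbers for weaker inhibition of growth), compound 2 gives 73700 nM and sits within the scatter of compound 1, so neither of the two can be ranked over the other. Compound 3 `O=S(=O)(Nc1ccc(Cl)c(F)c1)c1ccc(-c2cnc(C3CC3)o2)cc1` has not yet been measured. It differs from compound 2 by 4-chloro-3-fluorophenyl in place of 3-chloro-4-fluorophenyl on a sulfonamide nitrogen and carries 4-chloro-3-fluorophenyl in place of 3-chloro-4-fluorophenyl on a sulfonamide nitrogen. Among the measured compounds shown here, only one measured step bears on this change. That step (a 1.5-fold higher number from compound 1 to compound 2 (0.17 log units; within the scatter)) put 3-chloro-4-fluorophenyl in place of 2-chlorophenyl on the same nitrogen and stayed within the scatter. Compound 3 keeps the same atoms as compound 2, and no step beyond the scatter is expected in this assay for it. The expected step (a 1.1-fold lower number from compound 2 to compound 3 (0.05 log units; within the scatter)) rests on that single comparison, so the expectation is a loose one. For compound 3 the estimated value is 65000 nM with an expected range from 35000 nM to 110000 nM on this estimate.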

Compound 3, concentration for total growth inhibition: 63000 nM
For compound 3 the middle estimate is 1.0-fold (0.01 log units) above the measured one; low and high end bracket the measured number.
By their numbers in this assay, from the lowest: compounds 1, 3 and 2 (each within the scatter of the next).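

In this assay, exchanging the chlorine and the fluorine on the phenyl group at the sulfonamide nitrogen gives a 1.2-fold lower number from compound 2 to compound 3 (0.07 log units; within the scatter) and thus shows that two groups with the same atoms, joined differently, cannot be told apart at this place on this read-out. Set against the 2-chlorophenyl group of compound 1, the 4-chloro-3-fluorophenyl group gives a 1.3-fold higher number from compound 1 to compound 3 (0.10 log units; within the scatter) and so, together with the earlier step, places all three halogenated phenyl groups shown here within the scatter of one another, with no group ranked over another. Nothing measured alongside these growth numbers speaks to why the three groups read alike.

On these data alone, all three compounds carry a halogenated phenyl group on the sulfonamide nitrogen, so it remains open whether an amine or a carboxylic acid on that phenyl group, or a longer chain in its place, would give a number beyond the scatter in this assay and thereby show that this place matters at all. As far as these compounds go, it is also open whether a plain phenyl group with no halogen would read like these three.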